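The compounds below may be only part of what the source reports. "The series", "measured", "known", "first", "only" and "open" are said of these compounds alone.

In a functional assay on HO8910 cells (Homo sapiens) for cytotoxicity, read by CCK-8 assay, with a stated time of 24 h (on this read-out lower numbers stand for stronger inhibition and higher numbers for weaker inhibition), compound 1 `C/C(=C\c1cc(C2=CCCCC2)co1)C(N)=O` gives only a limit of > 50000 nM. Compound 2 `C/C(=C\c1cc(-c2ccc(C)cc2)cs1)C(N)=O` likewise returns only a limit, > 50000 nM, in this assay. Compound 2 thus stands at the same boundary as the other measured value, since both sit at the limit of > 50000 nM in this assay, at which 2 of the 2 values shown sit, and no number is known for either. Compound 3 `C=Cc1ccc(-c2csc(/C=C(\C)C(N)=O)c2)cc1` differs from compound 2 by vinyl in place of methyl on an aromatic carbon. Among the measured compounds shown here, no measured step is available, and no movement beyond the scatter is expected, a step that the limit leaves unreadable from compound 2 to compound 3. Compound 3 is accordingly estimated at 60000 nM, within 20000 nM to 200000 nM, most probably reported once more only as a limit.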

Compound 3, half-maximal inhibitory concentration: > 50000 nM
Compound 3: a limit, no number; the forecaster's own chance of this, stated with the estimate: 80%; the middle value is on the limit's open side.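

No step can be read from compound 2 to compound 3 in this assay, since each gives only a limit: the limit of > 50000 nM in this assay, at which 3 of the 3 values shown sit. The compounds shown leave open what real value any of them has and whether vinyl in place of methyl changes it.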